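The source may report more compounds than this note shows. Statements on the series, on what has been measured and on what is new or still open speak of the compounds shown alone.

Measured compounds in the series:
- compound 1, `O=C1COc2ccc(-c3cccc(NS(=O)(=O)c4ccc(F)cc4)c3)cc2N1C1CC1`: > 40000 nM
- compound 2, `COc1ccc(N2C(=O)COc3ccc(-c4cnc(OC)c(NS(=O)(=O)c5ccc(F)cc5)c4)cc32)cc1`: 1220 nM
- compound 3, `O=C1COc2ccc(-c3cnc(Cl)c(NS(=O)(=O)c4ccc(F)cc4)c3)cc2N1c1ccccc1`: 10300 nM

In a functional assay on HeLa cells (Homo sapiens) for antiproliferative activity, read by MTT assay, with a stated time of 72 h (on this read-out higher numbers stand for weaker inhibition and lower numbers for stronger inhibition), compound 1 returns only a limit, > 40000 nM, and not a number. That is the position described by the limit of > 40000 nM in this assay, at which 1 of the 3 values shown sits. Compound 2 and compound 3 carry an aryl group on the amide-type nitrogen of the shared core and both give measured numbers in this assay: compound 2 gives 1220 nM and compound 3 gives 10300 nM. Among the compounds with values here, they also differ from compound 1 elsewhere, so no single step connects them to compound 1 and nothing about the substituent on that nitrogen can be isolated from them.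

The unmeasured compound 4, `O=C1COc2ccc(-c3cccc(NS(=O)(=O)c4ccc(F)cc4)c3)cc2N1C1CCCCC1`, differs from compound 1 in one place: cyclohexyl in place of cyclopropyl on an amide-type nitrogen in a ring. Within the data shown here, no pair of measured compounds differs in that place alone, so there is no measured step to lean on. Given that compound 1 sits at the limit of this assay, the expectation for compound 4 is that it stays near that limit, with any change from compound 1 expected to be small in either direction or none beyond the scatter. Compound 4 is expected at 40000 nM, within a range from 10000 nM to 100000 nM; the step of a number no higher from compound 1 to compound 4 (the limit leaves the size open) is thus estimated to be close to flat.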

Compound 4, half-maximal inhibitory concentration: 10800 nM
Compound 4: the middle estimate sits 3.7-fold (0.57 log units) above what was measured; the measured number falls inside the stated range.
By their numbers in this assay, from the lowest: compound 2; then compounds 3 and 4 (each within the scatter of the next). At a limit, above all of these: compound 1.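

Cyclohexyl in place of cyclopropyl on the amide-type nitrogen in a ring gives an at least 3.7-fold lower number from compound 1 to compound 4 (0.56 log units; beyond the scatter) in this assay, and this is the only single-place step in the series so far. It shows that the read-out responds to the group at this position, which compound 2 and compound 3 could not show, as both also differ from compound 1 elsewhere. The size of the step stays open, since the value for compound 1 is only a limit: the limit of > 40000 nM in this assay, at which 1 of the 4 values shown sits.

As far as these compounds go, two carbocycles on one nitrogen give no trend, so it remains unknown whether the response follows ring size, the count of carbon atoms, or something specific to cyclohexyl; cyclobutyl, cyclopentyl, an open hexyl chain or a cyclohexyl ring carrying an amine or a carboxylic acid would help separate these readings. From the compounds shown here alone, it also remains open how an aryl group at this nitrogen, as carried by compound 2 and compound 3, would compare with cyclohexyl on the otherwise unchanged core of compound 4.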